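This account rests on a few compounds, and the source may have more. Where it says the series, first, only, none or still open, it means among the compounds named here.

In a functional assay on A2780 cells (Homo sapiens) for antiproliferative activity, read by MTT assay, with a stated time of 48 h (on this read-out lower numbers stand for stronger inhibition and higher numbers for weaker inhibition), compound 1 `CCNCC(=O)Nc1cc(OC)ccc1C(=O)c1ccc2c(c1)C=CC(C)(C)O2` gives 2070 nM. Compound 2 `COc1ccc(C(=O)c2ccc3c(c2)C=CC(C)(C)O3)c(NC(=O)CN(C)C)c1`, which carries the change (dimethylamino in place of ethylamino on a saturated chain carbon bound to a carbonyl carbon), gives 1020 nM in this assay, a step of a 2.0-fold lower number from compound 1 to compound 2 (0.31 log units; beyond the scatter). Compound 3 `CCNCC(=O)Nc1cc(OC)ccc1C(=O)c1cc(OC)c(OC)c(OC)c1` gives 950 nM in this assay; the difference between its core and the core of compound 1 is not broken down here, so nothing is made of that gap. Compound 4 `COc1ccc(C(=O)c2cc(OC)c(OC)c(OC)c2)c(NC(=O)CN(C)C)c1` has not yet been measured; it differs from compound 3 by dimethylamino in place of ethylamino on a saturated chain carbon bound to a carbonyl carbon, the same change as from compound 1 to compound 2, at a place described in the same words. For compound 4 the expected step is a 1.9-fold lower number from compound 3 to compound 4 (0.28 log units; within the scatter), which rests on the measured step of a 2.0-fold lower number from compound 1 to compound 2 (0.31 log units; beyond the scatter) in this assay. Compound 4 is therefore estimated at 500 nM, with a range from 250 nM to 1000 nM.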

Compound 4, half-maximal inhibitory concentration: 580 nM
Beside the measured number, compound 4's estimate is 1.2-fold (0.06 log units) below it; the range from low to high includes it.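

On the core of compound 3 the change gives a 1.6-fold lower number from compound 3 to compound 4 (0.21 log units; within the scatter), so taken alone this step cannot be told apart from repeat scatter. Set beside the earlier step, it does not differ from it: the same change on two cores in this assay, a 2.0-fold lower number (0.31 log units; beyond the scatter) from compound 1 to compound 2 and a 1.6-fold lower number (0.21 log units; within the scatter) from compound 3 to compound 4, 1.2-fold (0.09 log units) apart, within the scatter of two such steps. The two cores therefore agree on the size of the change, which fits its carrying over between them, but two cores give no general rule, and on the core of compound 3 the change alone is not shown to have any effect.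

The compounds shown leave open whether a cyclic amine such as pyrrolidine or morpholine in place of dimethylamino would follow the same step in this assay. They also leave open what a longer chain between the carbonyl and the amine would do.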